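Methoxy to trifluoromethyl on the shared core

A few compounds are considered here, and "the series" means these few. Any claim that something is new, unique, unknown or untested is made for them only; others in the source may bear on it.

In a toxicity assay on WI-38 cells (Homo sapiens) for inhibition, read by MTT assay, with a stated time of 72 h (on this read-out lower numbers stand for stronger inhibition and higher numbers for weaker inhibition), compound 3 (`COc1ccc(N2CCCC2)c(C(=O)Nc2ccc(CNC(=O)OCc3cccnc3)cc2)c1`) gives 35600 nM and compound 1 (`Cc1ccc(N2CCCC2)c(C(=O)Nc2ccc(CNC(=O)OCc3cccnc3)cc2)c1`) gives 40600 nM so the two lie within the scatter of each other. Compound 2 (`O=C(NCc1ccc(NC(=O)c2cc(-c3ccccc3)ccc2N2CCCC2)cc1)OCc1cccnc1`) reads > 100000 nM which is a limit of the assay. Compound 4 (`O=C(NCc1ccc(NC(=O)c2cc(C(F)(F)F)ccc2N2CCCC2)cc1)OCc1cccnc1`) carries trifluoromethyl in place of methoxy on an aromatic carbon para to a pyrrolidin-1-yl group. Within the data shown here, two measured steps bear on this change. Phenyl in place of methyl gave an at least 2.4-fold higher number from compound 1 to compound 2 (0.39 log units; beyond the scatter) as the one clear move. Trifluoromethyl brings no ring, so methoxy in place of methyl, a 1.1-fold lower number from compound 1 to compound 3 (0.06 log units; within the scatter) is taken as the closer guide and no step beyond the scatter is expected. The estimated move is a 1.3-fold higher number from compound 3 to compound 4 (0.10 log units; within the scatter) as a working figure. In this assay compound 4 is expected at 45000 nM with an estimated range from 20000 nM to 100000 nM for now.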

Compound 4, half-maximal inhibitory concentration: > 100000 nM
Compound 4 was reported as a limit; the forecaster's own chance of this, stated with the estimate: 15%; at least 2.2-fold (0.34 log units) between middle value and limit.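

Compound 4 reads as a limit of the assay, and at this position, para to a pyrrolidin-1-yl group, trifluoromethyl parts from both methoxy and methyl: an at least 2.8-fold higher number from compound 3 to compound 4 (0.44 log units; beyond the scatter), and an at least 2.4-fold higher number from compound 1 to compound 4 (0.39 log units; beyond the scatter). Until now only phenyl had given a step beyond the scatter here, so in this assay a group with no ring can do so too. The step between compound 2 and compound 4 cannot be read: the limit of > 100000 nM in this assay, at which 2 of the 4 values shown sit.

Going by these compounds, how far phenyl and trifluoromethyl differ stays open. So does whether an amine or a carboxylic acid at this position would read with compound 1 and compound 3 or at the limit.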